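Trimming the amide-side group in one antiproliferative series

A few compounds are considered here, and "the series" means these few. Any claim that something is new, unique, unknown or untested is made for them only; others in the source may bear on it.

Compound 1 `CCCSc1nc(Cl)c2c(n1)N(Cc1ccccc1)C(C(=O)Nc1ccccc1)N2` gives 50300 nM.
Compound 2 `CCCSc1nc(Cl)c2c(n1)N(Cc1ccco1)C(C(=O)N1CCN(C)CC1)N2` gives 13600 nM.
Compound 3 `CCCSc1nc(Cl)c2c(n1)N(Cc1ccccc1)C(C(=O)NCCC1=CCc3ccccc31)N2` gives 48800 nM.

All three were tested in a functional assay on A549 cells (Homo sapiens) for antiproliferative activity, read by MTT assay, with a stated time of 72 h; on this read-out lower numbers stand for stronger inhibition and higher numbers for weaker inhibition. Compound 3 stands second highest of the three numbers: compound 1 sits within the scatter of it, while compound 2 gives a lower number that lies beyond the scatter. Compound 4 `CCCSc1nc(Cl)c2c(n1)N(Cc1ccccc1)C(C(=O)NCC(C)C)N2` differs from compound 3 by a group of 3 heavy atoms (3 carbon; no ring) in place of a group of 10 heavy atoms (10 carbon; one five-membered non-aromatic ring of carbon only, one six-membered aromatic ring of carbon only), on a saturated chain carbon bound to an amide-type nitrogen. Among the compounds with values here, the one measured step that alters the group on the amide-type nitrogen is a 1.0-fold lower number from compound 1 to compound 3 (0.01 log units; within the scatter), and it moved the number by nothing beyond the scatter. On that basis the step of a 1.1-fold lower number from compound 3 to compound 4 (0.04 log units; within the scatter) is expected to remain within the scatter as well. Compound 4 is therefore estimated at 45000 nM, with a likely range from 20000 nM to 110000 nM.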

Compound 4, half-maximal inhibitory concentration: 48200 nM
Estimate against measurement, compound 4: 1.1-fold (0.03 log units) below, and the stated range covers the measured number.
By their numbers in this assay, from the lowest: compound 2; then compounds 4, 3 and 1 (each within the scatter of the next).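

In this assay, isopropyl in place of the two-ring group, on a saturated chain carbon bound to an amide-type nitrogen, gives a 1.0-fold lower number from compound 3 to compound 4 (0.01 log units; within the scatter), so this much smaller group holds the number as well as the two-ring group does. Isobutyl in place of phenyl on an amide-type nitrogen gives a 1.0-fold lower number from compound 1 to compound 4 (0.02 log units; within the scatter), so an open chain and an aromatic ring are not told apart here. No evidence bears on the reason for this. Going by these compounds, whether an amine or a carboxylic acid on this chain would move the number stays open. Compound 2 differs from the others in more than one place, so its lower number cannot be tied to any single group.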